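The compounds below may be only part of what the source reports. "The series", "measured", "known", "first", "only" and "open" are said of these compounds alone.

Working notes on the series. In a functional assay on THP-1 cells (Homo sapiens) for inhibition, with a stated time of 4 h (on this read-out lower numbers stand for stronger inhibition and higher numbers for weaker inhibition), compound 1 (`O=C(CN1CCCN(C(=O)c2ccccc2)C[C@H](NC(=O)c2ccccc2)C1=O)N[C@H]1CC(=O)OC1O`) gives 1020 nM and compound 2 (`O=CN1CCCN(CC(=O)N[C@H]2CC(=O)OC2O)C(=O)[C@@H](NC(=O)c2ccc3ccccc3c2)C1`) gives 219 nM as the lower of the two numbers, a gap beyond the scatter. Compound 3 (`CC(=O)N1CCCN(CC(=O)N[C@H]2CC(=O)OC2O)C(=O)[C@@H](NC(=O)c2ccc3ccccc3c2)C1`) has not yet been measured. It departs from compound 2 in one place: methyl in place of hydrogen on a carbonyl carbon as the counted change, which is methyl in place of hydrogen on a carbonyl carbon, or formyl to acetyl. For the measured compounds named here, no measured pair differing in one place is available to size this change, so the expectation rests on the small size of the change alone. The expectation in this assay is no step beyond the scatter, with a slight lean towards a higher number: the estimate means a 1.2-fold higher number from compound 2 to compound 3 (0.07 log units; within the scatter) as the likely outcome. Compound 3 is expected at 260 nM with 110 nM to 620 nM as the estimated range.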

Compound 3, half-maximal inhibitory concentration: 216 nM
The estimate for compound 3 lay 1.2-fold (0.08 log units) above the measured number, within the range that was stated.
By their numbers in this assay, from the lowest: compounds 3 and 2 (each within the scatter of the next); then compound 1.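

In this assay the step of a 1.0-fold lower number from compound 2 to compound 3 (0.01 log units; within the scatter) gives methyl in place of hydrogen on a carbonyl carbon its first measured size in this series. On this read-out, formyl and acetyl cannot be told apart at this place, a carbonyl carbon whose other neighbours are an amide-type nitrogen in a ring, so the one added carbon is tolerated in this pair. Nothing available bears on why the two compounds read alike.

As far as these compounds go, it remains open whether a longer chain such as propyl, or an amine, on this carbonyl carbon would also stay within the scatter of compound 2. A single pair also cannot show whether the same change would read alike with other groups on the shared core.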